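A few compounds are considered here, and "the series" means these few. Any claim that something is new, unique, unknown or untested is made for them only; others in the source may bear on it.

Compound 2, with the structure `Cc1cc2c(cc1Cc1ccc(C(=O)NC[C@H]3CC[C@H](C(=O)O)CC3)o1)C(C)(C)CCC2(C)C`, is one of two compounds assessed in an assay on isolated protein for binding affinity to Gonadotropin-releasing hormone receptor (Rattus norvegicus); on this read-out higher numbers stand for weaker inhibition and lower numbers for stronger inhibition. In this assay compound 2 gives 3000 nM, the higher of the two numbers. For the measured compounds named here, its only comparator is compound 1, with the structure `Cc1cc2c(cc1Cc1ccc(C(=O)NCC3CCCCC3)o1)C(C)(C)CCC2(C)C`, which in this assay gives 1550 nM; the step of a 1.9-fold higher number from compound 1 to compound 2 (0.29 log units; within the scatter) corresponds to a carboxy group in place of hydrogen on a saturated ring carbon and does not rise above the scatter.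

Compound 3, with the structure `CCOC(=O)[C@H]1CC[C@H](CNC(=O)c2ccc(Cc3cc4c(cc3C)C(C)(C)CCC4(C)C)o2)CC1`, carries the change (ethyl in place of hydrogen on an oxygen next to a carbonyl group), so the acid of compound 2 becomes an ethyl ester. Going by the values given here, no measured step matches this change. Among the compounds with values here, the one step that touches this part of the molecule, from compound 1 to compound 2, was small, so for compound 3 a step of about a 1.5-fold lower number from compound 2 to compound 3 (0.18 log units; within the scatter) in this assay is expected, with no direction clearly favoured. Compound 3 is therefore estimated at 2000 nM, most likely between 700 nM and 6000 nM.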

Compound 3, inhibition constant: 2730 nM
Estimate against measurement, compound 3: 1.4-fold (0.14 log units) below; low and high end bracket the measured number.
By their numbers in this assay, from the lowest: compounds 1, 3 and 2 (each within the scatter of the next).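

The earlier compounds shown here showed only a free carboxy group on this ring carbon, so it was unclear whether the hydrogen on that group's oxygen mattered. In this assay, ethyl in place of that hydrogen, on an oxygen next to a carbonyl group, gives a 1.1-fold lower number from compound 2 to compound 3 (0.04 log units; within the scatter) and so leaves the number within the scatter, as does the full ethoxycarbonyl group in place of the ring hydrogen, with a 1.8-fold higher number from compound 1 to compound 3 (0.25 log units; within the scatter) as its step. Across these three compounds, then, neither the plain cyclohexyl ring, the 4-carboxycyclohexyl group nor the 4-(ethoxycarbonyl)cyclohexyl group stands apart from the others.

The compounds shown leave open whether an amine, a hydroxymethyl group or a longer chain on this ring carbon would shift the number beyond the scatter. Nothing available explains why these numbers lie so close together.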